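The source may report more compounds than this note shows. Statements on the series, on what has been measured and on what is new or still open speak of the compounds shown alone.

Measured in an assay on isolated protein for inhibition of Amine oxidase [flavin-containing] B (Homo sapiens); on this read-out higher numbers stand for weaker inhibition and lower numbers for stronger inhibition:
compound 1, `C#CCNC1CCc2c(SCc3cccc(F)c3)cccc21`: 1480 nM
compound 2, `C#CCNC1CCc2c(SCc3cccc(Br)c3)cccc21`: > 100000 nM, a limit of the assay, not a number

Compound 2 thus stands only at the limit of this assay, (the limit of > 100000 nM in this assay, at which 1 of the 2 values shown sits), with no number behind it. Within the data shown here, the single measured step, an at least 67-fold higher number from compound 1 to compound 2 (1.82 log units; beyond the scatter), is large. Compound 3, `C#CCNC1CCc2c(SCc3cccc(OC)c3)cccc21`, differs from compound 2 by methoxy in place of bromo on an aromatic carbon. No measured step covers methoxy, and the one shown step says only that exchanging the halogen moved the value far, so the direction for compound 3 is open. A step back toward a readable number, an at least 5.0-fold lower number from compound 2 to compound 3 (0.69 log units; beyond the scatter), is expected, though a limit again remains possible. Compound 3 is estimated at 20000 nM, within a range from 2000 nM to 100000 nM.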

Compound 3, half-maximal inhibitory concentration: 3190 nM
Compound 3: the middle estimate sits 6.3-fold (0.80 log units) above what was measured, within the range that was stated.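

Methoxy in place of bromo on this aromatic carbon gives an at least 31-fold lower number from compound 2 to compound 3 (1.49 log units; beyond the scatter), so a readable value in this assay is not confined to fluoro at this position. Methoxy in place of fluoro gives a 2.2-fold higher number from compound 1 to compound 3 (0.33 log units; beyond the scatter), a modest step beside the large one seen with bromo. Compound 2 remains a limit of the assay, not a number: the limit of > 100000 nM in this assay, at which 1 of the 3 values shown sits.

Whether the loss belongs to bromo alone stays open, as chloro is not among the compounds shown. From the compounds shown here alone, how an amine, a carboxylic acid or a longer chain such as ethoxy would read at this position also stays open.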